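The source may report more compounds than this note shows. Statements on the series, on what has been measured and on what is new or still open speak of the compounds shown alone.

Within the data shown here, compound 1 `COc1cc2ncnc(Nc3ccc(F)c(Cl)c3)c2cc1OCCCCC(=O)Nc1ccc(S(N)(=O)=O)cc1` is tested in a functional assay on A-431 cells (Homo sapiens) for antiproliferative activity, read by MTT assay, with a stated time of 72 h (on this read-out lower numbers stand for stronger inhibition and higher numbers for weaker inhibition), where compound 1 gives 5020 nM, the second highest of the three numbers so far. Compound 2 `COc1cc2ncnc(Nc3ccc(Cl)c(C(F)(F)F)c3)c2cc1OCCCCC(=O)Nc1ccc(S(N)(=O)=O)cc1` gives 3910 nM, and the step of a 1.3-fold lower number from compound 1 to compound 2 (0.11 log units; within the scatter) lies within the scatter. Compound 3 `COc1ccc(Nc2ncnc3cc(OC)c(OCCCCC(=O)Nc4ccc(S(N)(=O)=O)cc4)cc23)cc1OC` gives 35400 nM, a modest step of a 7.1-fold higher number from compound 1 to compound 3 (0.85 log units; beyond the scatter) toward weaker inhibition. Compound 4 `COc1cc2ncnc(Nc3cc(F)c(F)c(F)c3)c2cc1OCCCCC(=O)Nc1ccc(S(N)(=O)=O)cc1` carries a new group at the same place: 3,4,5-trifluorophenyl in place of 3-chloro-4-fluorophenyl on a nitrogen on an aromatic ring. Of the measured steps, the exchange of 3-chloro-4-fluorophenyl for 4-chloro-3-(trifluoromethyl)phenyl, seen in a 1.3-fold lower number from compound 1 to compound 2 (0.11 log units; within the scatter), bears most closely and was flat, while a 9.1-fold higher number from compound 2 to compound 3 (0.96 log units; beyond the scatter) shows that only the 3,4-dimethoxyphenyl weakened inhibition. A step within the scatter, or slightly weaker, is therefore expected: a 1.2-fold higher number from compound 1 to compound 4 (0.08 log units; within the scatter). Compound 4 is estimated at 6000 nM, within 2500 nM to 15000 nM.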

Compound 4, half-maximal inhibitory concentration: 23400 nM
Beside the measured number, compound 4's estimate is 3.9-fold (0.59 log units) below it; measured number outside the range, above it.
By their numbers in this assay, from the lowest: compounds 2 and 1 (each within the scatter of the next); then compounds 4 and 3 (each within the scatter of the next).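

In this assay, a ring carrying only fluorine does not keep the level of the chlorine-bearing rings at this place, on a nitrogen on an aromatic ring: the change to 3,4,5-trifluorophenyl gives a 4.7-fold higher number from compound 1 to compound 4 (0.67 log units; beyond the scatter) and a 6.0-fold higher number from compound 2 to compound 4 (0.78 log units; beyond the scatter). Instead it falls level with the 3,4-dimethoxyphenyl compound, with a 1.5-fold lower number from compound 3 to compound 4 (0.18 log units; within the scatter), so among these four compounds only the two with chlorine on this ring form the stronger pair. Nothing available explains this split.

From the compounds shown here alone, whether chlorine itself separates the two levels remains open. A 3,4,5-trichlorophenyl group on the same nitrogen would bear directly on that question.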